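Amide chain extension from compound 3 to compound 4

A few compounds are considered here, and "the series" means these few. Any claim that something is new, unique, unknown or untested is made for them only; others in the source may bear on it.

Measured in a functional assay on cells (Platelet, Homo sapiens) for inhibition; a higher number here means a weaker inhibitor, a lower number a stronger inhibitor:
compound 1 `O=C(O)c1ccc(-c2nn(Cc3ccccc3)c3ccccc23)cc1`: > 10000 nM
compound 2 `COC(=O)c1ccc(-c2nn(Cc3ccccc3)c3ccccc23)cc1`: > 10000 nM
compound 3 `CNC(=O)c1ccc(-c2nn(Cc3ccccc3)c3ccccc23)cc1`: > 10000 nM

Compound 3 gives > 10000 nM, which is a limit and not a number. The whole set sits at the limit of > 10000 nM in this assay, at which 3 of the 3 values shown sit.

Compound 4 `CCCNC(=O)c1ccc(-c2nn(Cc3ccccc3)c3ccccc23)cc1` differs from compound 3 by ethyl in place of hydrogen on a saturated chain carbon bound to an amide-type nitrogen, so that methylamino becomes propylamino.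

The measured changes at the carbonyl carbon are a step that the two limits leave unreadable from compound 1 to compound 2, a step that the two limits leave unreadable from compound 1 to compound 3 and a step that the two limits leave unreadable from compound 2 to compound 3. None of them gives a size to carry over. With only a step that the two limits leave unreadable from compound 2 to compound 3 as the nearest guide, no step beyond the scatter is expected in this assay, and another limit is the likeliest report.

The expected change is a step that the limit leaves unreadable from compound 3 to compound 4.

For compound 4 the estimated value is 15000 nM, with an expected range of 5000 nM to 40000 nM.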

Compound 4, half-maximal inhibitory concentration: > 10000 nM
Compound 4 ended at the assay's limit; the forecaster's own chance of this, stated with the estimate: 75%; the middle value is on the limit's open side.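

In this assay, among the compounds shown here, compound 4 gives > 10000 nM, which is a limit and not a number, so no step linking it to compound 1, compound 2 or compound 3 can be read. The compounds shown leave open what any change at the carbonyl carbon does to inhibition, because the whole series sits at one limit: the limit of > 10000 nM in this assay, at which 4 of the 4 values shown sit.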